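The compounds below may be only part of what the source reports. "The series", "measured", "known", "first", "only" and "open" are said of these compounds alone.

Measured in an assay on mitochondria for inhibition of Amine oxidase [flavin-containing] A (Bos taurus), read by fluorescence, with a stated time of 60 min; on this read-out higher numbers stand for weaker inhibition and lower numbers for stronger inhibition:
compound 1 `COC(=O)CN1C(=O)c2ccccc2NC1c1ccccc1` gives 930 nM
compound 2 `NNC(=O)CN1C(=O)c2ccccc2NC1c1ccccc1` gives 38 nM
compound 3 `COC(=O)CCN1C(=O)c2ccccc2NC1c1ccccc1` gives 92 nM

Compound 3 stands second highest of the three numbers. Its nearest neighbour is compound 2, with a 2.4-fold higher number from compound 2 to compound 3 (0.38 log units; beyond the scatter), and its furthest is compound 1, with a 10-fold lower number from compound 1 to compound 3 (1.00 log units; beyond the scatter). Compound 4 `COC(=O)CCN1C(=O)c2ccccc2NC1c1ccc(Cl)cc1` differs from compound 3 by chloro in place of hydrogen on an aromatic carbon; the same difference, cut one bond further out, reads phenyl to 4-chlorophenyl. Within the data shown here, none of the measured steps touches that ring: the step of a 24-fold lower number from compound 1 to compound 2 (1.39 log units; beyond the scatter) and the step of a 10-fold lower number from compound 1 to compound 3 (1.00 log units; beyond the scatter) both alter the chain on the ring nitrogen and leave the phenyl as it is. Among the measured compounds shown here, no measured step therefore bears directly on the change, and the chain carrying the (methoxycarbonyl)methyl group of compound 3 is kept in compound 4. In this assay a step of no more than modest size in either direction, possibly none beyond the scatter, is expected. The expected step is a 1.3-fold lower number from compound 3 to compound 4 (0.12 log units; within the scatter). Compound 4 is estimated at 70 nM, with a range from 25 nM to 250 nM.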

Compound 4, half-maximal inhibitory concentration: 98 nM
Estimate against measurement, compound 4: 1.4-fold (0.15 log units) below, within the range that was stated.
By their numbers in this assay, from the lowest: compound 2; then compounds 3 and 4 (each within the scatter of the next); then compound 1.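

In this assay, chloro in place of hydrogen on an aromatic carbon, para to a large group, gives a 1.1-fold higher number from compound 3 to compound 4 (0.03 log units; within the scatter) and so moves the number by no more than the usual scatter. The earlier steps shown here all altered the chain on the ring nitrogen and all lay beyond the scatter, whereas this one shows that, with the chain of compound 3 kept, the phenyl carries a chlorine at this position with no change that can be read. Nothing available explains why this change leaves the number in place.

On these data alone, whether chloro reads the same on the aminocarbamoyl chain of compound 2 or on the chain of compound 1 stays open. Also open, as far as these compounds go, is how other groups at this position would read, such as an amine, a carboxylic acid or a nitrile.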